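Replacing pyridin-4-yl with 2-phenylethenyl on a shared core

A few compounds are considered here, and "the series" means these few. Any claim that something is new, unique, unknown or untested is made for them only; others in the source may bear on it.

Compounds measured in a physicochemical assay for lipophilicity, measured as octanol-water partition; a lower number here means a more polar compound, a higher number a more lipophilic compound:
- compound 1 `O=C(NNc1ccnc2cc(Cl)ccc12)c1ccccc1/N=C/c1cccc(Cl)c1Cl`: 6.1
- compound 2 `O=C(NNc1ccnc2cc(Cl)ccc12)c1ccccc1/N=C/c1ccncc1`: 3.86

Of these two, compound 2 stands lowest at 3.86, with compound 1 beyond the scatter above it. The next structure, compound 3 `O=C(NNc1ccnc2cc(Cl)ccc12)c1ccccc1/N=C/C=C/c1ccccc1`, keeps the shared core and carries 2-phenylethenyl in place of pyridin-4-yl on a carbon with a double bond to nitrogen.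

For the measured compounds named here, one measured step bears on this change: a number 2.24 log units lower from compound 1 to compound 2 (beyond the scatter), where pyridin-4-yl took the place of 2,3-dichlorophenyl. The new change runs the other way in one respect, since pyridin-4-yl leaves and a group with a six-membered aromatic ring of carbon only enters. A large rise in this assay is therefore expected. The entering group is not 2,3-dichlorophenyl, however, so the whole of that earlier step need not return. The estimated step is a number 1.64 log units higher from compound 2 to compound 3 (beyond the scatter). Compound 3 is estimated at 5.5, with an expected range from 4.9 to 6.1.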

Compound 3, partition coefficient: 5.54
Compound 3: middle estimate off by 0.04 log units, on the low side, and the stated range covers the measured number.
By their numbers in this assay, from the lowest: compound 2; then compound 3; then compound 1.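

In this assay, the position on a carbon with a double bond to nitrogen now proves to move the number upward as well as downward: 2-phenylethenyl in place of pyridin-4-yl gives a number 1.68 log units higher from compound 2 to compound 3 (beyond the scatter). The earlier compounds shown here showed a high number only with 2,3-dichlorophenyl, whereas this entering group holds no chlorine and still recovers most of the earlier difference, while 2,3-dichlorophenyl stays on top with a number 0.56 log units lower from compound 1 to compound 3 (beyond the scatter). No measurement at hand accounts for the size of either step.

The three compounds change the ring and the link to it together, so the share of the double bond in 2-phenylethenyl stays apart from that of the carbon-only ring only with groups such as unsubstituted phenyl or saturated 2-phenylethyl at the same place. From the compounds shown here alone, how far the number would fall with a basic amine such as morpholine, or with a carboxylic acid, at this position also remains open.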